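This account rests on a few compounds, and the source may have more. Where it says the series, first, only, none or still open, it means among the compounds named here.

Measured compounds:
Compound 1 `Oc1cccc2[nH]c(-c3ccc(-c4ccc(-c5ccccc5)cc4)cc3)nc12` gives 1110 nM in a functional assay on Gurav cells (Homo sapiens) for inhibition, read by sulforhodamine B assay; on this read-out lower numbers stand for stronger inhibition of growth and higher numbers for weaker inhibition of growth.
Compound 2 `Oc1cccc2[nH]c(-c3ccc(-c4ccc(-c5ccc(F)cc5)cc4)cc3)nc12` gives 2860 nM in this assay.
Compound 3 `Cc1ccc2[nH]c(-c3ccc(-c4ccc(-c5ccccc5)cc4)cc3)nc2c1` gives 3310 nM in this assay.

The study compares two pairs built on different cores. Compound 1 and compound 2 share one core and differ by fluoro in place of hydrogen on an aromatic carbon. That change gave a 2.6-fold higher number from compound 1 to compound 2 (0.41 log units; beyond the scatter), so the fluorinated compound 2 inhibits growth less strongly than compound 1. Compound 3 carries the other core; how it differs from compound 1 is not broken down here. In this assay compound 3 stands at the highest of the three numbers, close to compound 2 and beyond the scatter from compound 1.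

Compound 4 `Cc1ccc2[nH]c(-c3ccc(-c4ccc(-c5ccc(F)cc5)cc4)cc3)nc2c1` has not yet been measured. It relates to compound 3 as compound 2 relates to compound 1: the difference is fluoro in place of hydrogen on an aromatic carbon, and the place of the change is the same in both pairs, so it is the same change made on a second core. Because the step of a 2.6-fold higher number from compound 1 to compound 2 (0.41 log units; beyond the scatter) was modest but beyond the scatter, the same change on compound 3 is expected to weaken growth inhibition by a similar amount, giving an estimated step of a 2.3-fold higher number from compound 3 to compound 4 (0.36 log units; beyond the scatter). This expectation rests on one measured pair only, so the range is kept wide. Compound 4 is therefore expected to give about 7500 nM in this assay, with an estimated range from 3500 nM to 18000 nM.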

Compound 4, concentration for 50% growth inhibition: 16500 nM
Compound 4: the middle estimate sits 2.2-fold (0.34 log units) below what was measured; low and high end bracket the measured number.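

On the second core, the change from phenyl to 4-fluorophenyl again raised the number in this assay, with a 5.0-fold higher number from compound 3 to compound 4 (0.70 log units; beyond the scatter), so fluoro in place of hydrogen weakened growth inhibition on both cores shown. The two steps point the same way and their sizes cannot be told apart: the same change on two cores in this assay, a 2.6-fold higher number (0.41 log units; beyond the scatter) from compound 1 to compound 2 and a 5.0-fold higher number (0.70 log units; beyond the scatter) from compound 3 to compound 4, 1.9-fold (0.29 log units) apart, within the scatter of two such steps. This shows that the direction of the change carried from one core to the other and that the step measured on the first core was a fair guide to the second, but it does not show that the change costs more on one core than on the other, it gives no reason for the loss, and two pairs do not make a rule for further cores in this series.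

The compounds shown leave open whether a chloro, a methoxy or an amine in the same place, para to the large group, would raise the number as fluoro does, or whether the loss belongs to fluoro alone. They also leave open whether the same step would appear on a core that carries neither the hydroxyl group of compound 1 nor the methyl group of compound 3.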